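Series notes: compounds 1 to 3, cell growth inhibition

The source may hold more compounds than are shown below. What is called first, only, known or untested is meant among the compounds shown, and "the series" means these compounds.

Measured so far:
compound 1 `O=C(NCc1ccc(F)cc1)c1nc(Br)c2cccnc2c1NCCCNc1c(C(=O)NCc2ccc(F)cc2)nc(Br)c2cccnc12` — in a functional assay on HCT-116 cells (Homo sapiens) for cytotoxicity, read by MTT assay, with a stated time of 72 h (on this read-out lower numbers stand for stronger inhibition and higher numbers for weaker inhibition), compound 1 gives > 20000 nM, a limit of the assay rather than a number.
compound 2 `C[C@@H](Nc1c(C(=O)NCc2ccc(F)cc2)nc(Br)c2cccnc12)c1ccccc1` — in this assay compound 2 gives > 20000 nM, also a limit.

Compound 1 carries two copies of the shared core joined through a chain, whereas compound 2 carries a single core with (1-phenylethyl)amino on the aromatic nitrogen. Both values shown sit at the same limit (the limit of > 20000 nM in this assay, at which 2 of the 2 values shown sit), so compound 2 stands nowhere distinguishable from compound 1 in this assay: neither shows measurable inhibition within the tested range.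

Compound 3 `NCCNc1c(C(=O)NCc2ccc(F)cc2)nc(Br)c2cccnc12` differs from compound 2 in one place: 2-aminoethyl in place of 1-phenylethyl on a nitrogen on an aromatic ring. Going by the values given here, no step between measured compounds exists to calibrate this change. With both known values at the limit, nothing in the data points to a gain on going from compound 2 to compound 3, and the step is expected to be none beyond the scatter, a step that the limit leaves unreadable from compound 2 to compound 3. Compound 3 is accordingly estimated at 25000 nM, with a range from 8000 nM to 60000 nM, and is most likely to be reported once more only as a limit.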

Compound 3, half-maximal inhibitory concentration: > 20000 nM
Compound 3 ended at the assay's limit; the forecaster's own chance of this, stated with the estimate: 75%; the middle value is on the limit's open side.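

No step can be read from compound 2 to compound 3, or between either of them and compound 1, since all sit at one limit, not at numbers: the limit of > 20000 nM in this assay, at which 3 of the 3 values shown sit.

The compounds shown leave open how compound 1, compound 2 and compound 3 order against one another, and which group on the aromatic nitrogen, if any, gives a measurable value.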